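From hydroxy to sulfanyl: what to expect of compound 4

The source may report more compounds than this note shows. Statements on the series, on what has been measured and on what is new or still open speak of the compounds shown alone.

In a functional assay on A549 cells (Homo sapiens) for cytotoxicity, read by MTT assay (a lower number here means a stronger inhibitor, a higher number a weaker inhibitor), compound 1 `COc1cccc(-c2cc(-c3c(O)c4ccccc4oc3=O)nc(N)c2C#N)c1` gives 2380 nM and compound 2 `O=c1oc2ccccc2c(O)c1-c1cc(-c2ccc(F)cc2)nc(O)n1` gives 2390 nM, two values within the scatter of each other. Compound 3 `O=c1oc2ccccc2c(O)c1-c1cc(-c2c(F)cccc2Cl)nc(O)n1` gives 5100 nM, the highest number of the three, which makes it the weakest inhibitor measured so far.

Compound 4 `O=c1oc2ccccc2c(O)c1-c1cc(-c2c(F)cccc2Cl)nc(S)n1` changes one group of compound 3: sulfanyl in place of hydroxy on an aromatic carbon. In words, this is sulfanyl in place of hydroxy on an aromatic carbon, and that carbon sits between two ring nitrogen atoms.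

Among the compounds with values here, only one measured step compares compounds that differ in a single place: a 2.1-fold higher number from compound 2 to compound 3 (0.33 log units; beyond the scatter). That step is modest, and it concerns the 2-chloro-6-fluorophenyl group rather than the hydroxy group. Within the data shown here, no measured compound has a sulfanyl group, so the data give no direction for this swap, and the modest size of that one step is the only guide to scale in this assay. The expected result is therefore no change beyond the scatter, with an estimated step of a 1.3-fold lower number from compound 3 to compound 4 (0.11 log units; within the scatter). For compound 4, the estimated value is 4000 nM, with an expected range of 1600 nM to 10000 nM.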

Compound 4, half-maximal inhibitory concentration: 3980 nM
Beside the measured number, compound 4's estimate is 1.0-fold (0.00 log units) above it; the range from low to high includes it.
By their numbers in this assay, from the lowest: compounds 1, 2, 4 and 3 (each within the scatter of the next, the first and the last beyond it).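

In this assay the exchange of hydroxy for sulfanyl gives a 1.3-fold lower number from compound 3 to compound 4 (0.11 log units; within the scatter) and so stays within the scatter: on this carbon, between two ring nitrogen atoms, replacing oxygen with sulfur has no effect that this assay can detect. Within the data shown here, the one earlier step concerned the 2-chloro-6-fluorophenyl group, so this is the first measured information about this position, and it shows that, with that aryl group in place, the sulfanyl and hydroxy forms cannot be told apart here. No measurement shown explains why the two compounds read alike.

On these data alone, two single swaps of this kind cannot show how much this position tolerates, so it remains open whether a larger or different group there, such as a methyl group, a carboxylic acid or a longer chain, would shift the number beyond the scatter. As far as these compounds go, it is also open whether sulfanyl in place of hydroxy would read the same with the 4-fluorophenyl group of compound 2, since the present result comes from only one aryl setting.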